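Swapping Methyl for Fluoro on a Shared Core

This account rests on a few compounds, and the source may have more. Where it says the series, first, only, none or still open, it means among the compounds named here.

Compound 1 `Cc1ccc(NC(=S)N/N=C2\C(=O)Nc3ccc([N+](=O)[O-])cc32)cc1` was tested in a functional assay on the whole organism for inhibition, with Lemna aequinoctialis as the target, tested at 100 ug/mL (on this read-out lower numbers stand for less inhibition of growth and higher numbers for more inhibition of growth at the one concentration tested), where compound 1 gives 20%. Two near relatives stand beside it: compound 2 `COc1ccc(NC(=S)N/N=C2\C(=O)Nc3ccc([N+](=O)[O-])cc32)cc1` gives 15% in this assay, and compound 3 `O=C1Nc2ccc([N+](=O)[O-])cc2/C1=N/NC(=S)Nc1ccccc1C(F)(F)F` gives 15%. Of the three numbers that of compound 1 is the highest, but both gaps lie within the scatter, so no order among the three can be read from them. Among the measured compounds shown here, the only measured step that alters a single place is a number 5 percentage points lower from compound 1 to compound 2 (within the scatter), methoxy in place of methyl on an aromatic carbon, and it stays within the scatter. Compound 4 `O=C1Nc2ccc([N+](=O)[O-])cc2/C1=N/NC(=S)Nc1ccc(F)cc1` differs from compound 1 by fluoro in place of methyl on an aromatic carbon. For the measured compounds named here, no measured step exchanges methyl for fluoro; the one measured exchange of that same methyl stayed within the scatter, and all three measured numbers sit close together. The step in this assay is therefore expected to be a number 2 percentage points lower from compound 1 to compound 4 (within the scatter). Compound 4 is estimated at 18%, with a range from 5% to 32%.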

Compound 4, percent growth inhibition at one concentration: 15%
Compound 4: middle estimate off by 3 percentage points, on the high side; the range from low to high includes it.
By their numbers in this assay, from the lowest: compounds 2, 3, 4 and 1 (each within the scatter of the next).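

At this aromatic carbon, para to a large group, the change shows a number 5 percentage points lower from compound 1 to compound 4 (within the scatter) in this assay, so a second replacement of the methyl, now by fluoro, stays as close as the methoxy replacement did. The exchange between the two replacing groups adds no change at the digits printed from compound 2 to compound 4 (within the scatter), which means that methyl, methoxy and fluoro cannot be told apart at this position on this read-out. Nothing among the data offers an explanation for how closely these numbers sit together.

On these data alone, whether an amine, a carboxylic acid or a longer chain at this same carbon would move the number beyond the scatter stays open. Also open, as far as these compounds go, is whether methyl, methoxy and fluoro would stay this close at any concentration other than the single one tested.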